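Adding a Second Fluorine on a Different Core

This account rests on a few compounds, and the source may have more. Where it says the series, first, only, none or still open, it means among the compounds named here.

Four compounds share a long structure and differ only at one end, where a six-membered aromatic ring of carbon sits on an aromatic amide. Compound 2 `COc1cc2c(Oc3ccc(NC(=O)c4cc(-c5ccccc5)ccn4)cc3F)ccnc2cc1OCCCN1CCCCC1` carries that ring bare. In a functional assay on U-87MG ATCC cells (Homo sapiens) for cytotoxicity, read by MTT assay, with a stated time of 72 h (a higher number here means a weaker inhibitor, a lower number a stronger inhibitor), compound 2 gives 790 nM. Compound 1 `COc1cc2c(Oc3ccc(NC(=O)c4cc(-c5ccc(F)cc5)ccn4)cc3F)ccnc2cc1OCCCN1CCCCC1` differs from it by fluoro in place of hydrogen on an aromatic carbon, and in this assay compound 1 gives 12500 nM, so that a 16-fold higher number from compound 2 to compound 1 (1.20 log units; beyond the scatter).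

Compound 3 `COc1cc2c(Oc3ccc(NC(=O)c4nccc(-c5ccc(F)cc5)n4)cc3F)ccnc2cc1OCCCN1CCCCC1` is built on a different core; how that core differs from the core of compound 2 is not broken down here, and in this assay compound 3 gives "not determined" (no result reported), so no number for compound 3 was reported. Compound 4 `COc1cc2c(Oc3ccc(NC(=O)c4nccc(-c5ccc(F)cc5F)n4)cc3F)ccnc2cc1OCCCN1CCCCC1` differs from compound 3 by fluoro in place of hydrogen on an aromatic carbon. This is the same kind of change as the step from compound 2 to compound 1, though the place is not identical: in the earlier step the incoming fluoro is para to a large group, whereas here it is ortho to a large group and meta to a fluoro group.

Among the measured compounds shown here, since the only measured step of this kind was large and made the number go up, and since compound 3 itself has no number, the expectation for compound 4 rests mainly on compound 1 with 12500 nM as the nearest measured relative. Compound 4 is therefore expected to give about 10000 nM in this assay, with a wide range from 1500 nM to 60000 nM.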

Compound 4, half-maximal inhibitory concentration: 780 nM
The estimate for compound 4 lay 13-fold (1.11 log units) above the measured number; measured number outside the range, below it.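

In this assay, among the compounds shown here, compound 4 gives 780 nM while compound 3 has no number to set against it, so no step from compound 3 to compound 4 can be read. The compounds shown leave open whether the change seen a 16-fold higher number from compound 2 to compound 1 (1.20 log units; beyond the scatter) has any counterpart when a second fluorine is added on the other core. No measurement shown here offers an explanation for the value of compound 4.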